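A few compounds are considered here, and "the series" means these few. Any claim that something is new, unique, unknown or untested is made for them only; others in the source may bear on it.

The shared core of compound 1 `Cc1cccc(NC(=O)c2ccc3cccc(O)c3n2)c1` carries a 3-methylphenyl group on an amide-type nitrogen. In an ADME assay on THP-1 cells (Homo sapiens) for cytotoxicity, read by WST assay, with a stated time of 24 h (on this read-out higher numbers stand for weaker inhibition and lower numbers for stronger inhibition), compound 1 gives only a limit of the assay, > 30000 nM, so no number is known for it. Compound 2 `O=C(Nc1ccccc1Br)c1ccc2cccc(O)c2n1` carries a 2-bromophenyl group in the same position. In this assay compound 2 likewise gives a limit, > 30000 nM. Because both sit at the limit of > 30000 nM in this assay, at which 2 of the 2 values shown sit, the step that the two limits leave unreadable from compound 1 to compound 2 cannot be read, and it neither supports nor rules out any effect of swapping a methyl for a bromo group on that ring.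

Compound 3 `O=C(Nc1cccc(Br)c1)c1ccc2cccc(O)c2n1` is compound 1 with a single change: bromo in place of methyl on an aromatic carbon. Among the compounds with values here, nothing measured bears directly on this step, since the only comparison available, from compound 1 to compound 2, is hidden by the limits. The two measured compounds together show that small changes on this aryl ring have so far left the read-out at the limit.

Compound 3 is therefore expected in this assay to sit near 30000 nM, within 15000 nM to 60000 nM, most likely again as a limit rather than a number. The step expected from compound 1 to compound 3 is a number no higher from compound 1 to compound 3 (the limit leaves the size open), essentially none beyond the scatter.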

Compound 3, half-maximal inhibitory concentration: > 30000 nM
Compound 3: a limit, no number; the forecaster's own chance of this, stated with the estimate: 80%; the middle value sits exactly at the limit.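

In this assay compound 3 gives only a limit and not a number, as do compound 1 and compound 2, so no step among these three compounds can be read: the limit of > 30000 nM in this assay, at which 3 of the 3 values shown sit. The compounds shown leave open how far apart their true values lie, and whether any change on this aryl ring would give a measurable number.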